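The compounds below may be only part of what the source reports. "The series", "measured", "known", "first", "only" and "open" are said of these compounds alone.

Compounds measured in a functional assay on L1210 cells (Mus musculus) for inhibition, read by cell counting, with a stated time of 2 days; on this read-out lower numbers stand for stronger inhibition and higher numbers for weaker inhibition:
- compound 1 `C=C(Br)C(=O)Nc1cccc(-c2cn3nc(Cc4cccc(OC)c4)sc3n2)c1` gives 2000 nM
- compound 3 `COc1cccc(Cc2nn3cc(-c4cccc(N)c4)nc3s2)c1` gives 21000 nM
- compound 2 `COc1ccc(-c2nn3cc(-c4cccc(N)c4)nc3s2)cc1` gives only a limit of the assay, >= 250000 nM

Among the two plain numbers, compound 1 has the lowest, so the strongest inhibition shown. Among the measured compounds shown here, the only measured step, an 11-fold higher number from compound 1 to compound 3 (1.02 log units; beyond the scatter), puts hydrogen in place of (1-bromoethenyl)carbonyl on a nitrogen on an aromatic ring, and weakens inhibition markedly.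

Compound 4 `C=C(Br)C(=O)Nc1cccc(-c2cn3nc(-c4ccc(Cl)cc4)sc3n2)c1` keeps that group and changes the other end: 4-chlorophenyl in place of 3-methoxybenzyl on an aromatic carbon. For the measured compounds named here, no measured step alters this part of the molecule. Compound 2, whose ring joins the core without the intervening methylene, reaches (the limit of >= 250000 nM in this assay, at which 1 of the 3 values shown sits). That hint is weak, since compound 2 also lacks the acrylamide, so no direction can be firmly expected. Compound 4 is estimated at 4000 nM, between 800 nM and 40000 nM. The expected step of a 2.0-fold higher number from compound 1 to compound 4 (0.30 log units; within the scatter) would stay within the usual scatter.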

Compound 4, half-maximal inhibitory concentration: 1400 nM
Beside the measured number, compound 4's estimate is 2.9-fold (0.46 log units) above it, and the stated range covers the measured number.
By their numbers in this assay, from the lowest: compounds 4 and 1 (each within the scatter of the next); then compound 3. At a limit, above all of these: compound 2.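

Here the 3-methoxybenzyl group can be exchanged for 4-chlorophenyl with no real loss in this assay: a 1.4-fold lower number from compound 1 to compound 4 (0.15 log units; within the scatter). An aromatic ring joined directly to the core, without the intervening methylene, is therefore compatible with inhibition when the (1-bromoethenyl)carbonyl group is kept. Compound 2, which lacks that group, gives only a limit of the assay: the limit of >= 250000 nM in this assay, at which 1 of the 4 values shown sits.

As far as these compounds go, it remains open whether this position also accepts a non-aromatic group, such as an amine or a carboxylic acid. A plain phenyl ring there would show whether the chlorine matters.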